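Fluoro for Hydrogen: One Step, Seen Twice

The source may hold more compounds than are shown below. What is called first, only, known or untested is meant among the compounds shown, and "the series" means these compounds.

In a functional assay on HeLa cells (Homo sapiens) for cytotoxicity, read by MTT assay, with a stated time of 2 days (on this read-out higher numbers stand for lower toxicity in this test and lower numbers for higher toxicity in this test), the measured compounds give:
compound 1 `COc1ccc(-c2cc3cc(-c4ccccc4)cc(C(C)=O)c3[nH]2)cc1` gives 18900 nM
compound 2 `COc1ccc(-c2cc3cc(-c4ccc(F)cc4)cc(C(C)=O)c3[nH]2)cc1` gives 42800 nM
compound 3 `CC(=O)c1cc(/C=C/c2ccccc2)cc2cc(-c3ccc(F)cc3)[nH]c12` gives 16100 nM

Compound 1 and compound 2 differ by fluoro in place of hydrogen on an aromatic carbon, and this brought a 2.3-fold higher number from compound 1 to compound 2 (0.35 log units; beyond the scatter). Compound 4 `CC(=O)c1cc(/C=C/c2ccc(F)cc2)cc2cc(-c3ccc(F)cc3)[nH]c12` has not yet been measured; it differs from compound 3 by fluoro in place of hydrogen on an aromatic carbon, at the same place as before, so it is the same change. How the core of compound 3 differs from the core of compound 1 is not broken down here. Among the compounds with values here, as compound 3 and compound 1 lie within the scatter of each other, the single earlier step is the best guide. For compound 4 the expected step is a 2.2-fold higher number from compound 3 to compound 4 (0.35 log units; beyond the scatter), resting on the step seen in a 2.3-fold higher number from compound 1 to compound 2 (0.35 log units; beyond the scatter). Compound 4 is therefore estimated at 36000 nM, likely between 16000 nM and 85000 nM.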

Compound 4, concentration lethal to 50% of the cells: 5680 nM
Compound 4: the middle estimate sits 6.3-fold (0.80 log units) above what was measured; the measured number lies below the stated range.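

In this assay, the fluoro change did not carry over from one core to the other, giving a 2.8-fold lower number from compound 3 to compound 4 (0.45 log units; beyond the scatter). This step runs in the opposite direction to the earlier one, and the gap is too large to put down to ordinary measurement scatter: the same change on two cores in this assay, a 2.3-fold higher number (0.35 log units; beyond the scatter) from compound 1 to compound 2 and a 2.8-fold lower number (0.45 log units; beyond the scatter) from compound 3 to compound 4, 6.4-fold (0.81 log units) apart, beyond the scatter of two such steps. Within the data shown here, this shows that, across these two cores, the step seen on one gave no reliable guide to the other, but with only one pair per core it does not show which difference between the cores matters.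

The compounds shown leave open how a chloro group or an amine in place of the fluoro would behave on each core. They also leave open whether a longer chain in place of the 2-phenylethenyl group would change the step.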